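Swapping Methoxy for Dimethylamino on the Shared Core

A few compounds are considered here, and "the series" means these few. Any claim that something is new, unique, unknown or untested is made for them only; others in the source may bear on it.

Three measured compounds share one core. Compound 1 `CN(C)c1ncnc2c1c(-c1ccsc1)cn2[C@@H]1O[C@H](CO)[C@@H](O)[C@H]1O` carries dimethylamino and thiophen-3-yl; in a functional assay on CCRF-CEM cells (Homo sapiens), read by MTT assay, with a stated time of 72 h (on this read-out higher numbers stand for weaker inhibition and lower numbers for stronger inhibition), compound 1 gives 3480 nM. Compound 2 `COc1ncnc2c1c(-c1ccoc1)cn2[C@@H]1O[C@H](CO)[C@@H](O)[C@H]1O` carries methoxy and furan-3-yl, and in this assay compound 2 gives 110 nM. Compound 3 `COc1ncnc2c1c(-c1cccs1)cn2[C@@H]1O[C@H](CO)[C@@H](O)[C@H]1O` carries methoxy and thiophen-2-yl; in this assay compound 3 gives 90 nM, the lowest of the three numbers, although the step of a 1.2-fold lower number from compound 2 to compound 3 (0.09 log units; within the scatter) is within the scatter, while compound 1 sits far higher. Compound 4 `CN(C)c1ncnc2c1c(-c1cccs1)cn2[C@@H]1O[C@H](CO)[C@@H](O)[C@H]1O` differs from compound 3 by dimethylamino in place of methoxy on an aromatic carbon. For the measured compounds named here, no measured pair isolates this change: compound 1 and compound 3 differ both here and in thiophen-3-yl against thiophen-2-yl. Going by the values given here, still, the values of compound 1 and compound 3 show the dimethylamino compound much weaker than either methoxy compound, and the only measured step, a 1.2-fold lower number from compound 2 to compound 3 (0.09 log units; within the scatter), shows that exchanging the five-membered group changes little. Compound 4 is therefore expected to lose strongly, by a 28-fold higher number from compound 3 to compound 4 (1.44 log units; beyond the scatter). Compound 4 is estimated at 2500 nM in this assay, with a range from 800 nM to 8000 nM.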

Compound 4, half-maximal inhibitory concentration: > 20000 nM
Compound 4 gave a limit, no number; the forecaster's own chance of this, stated with the estimate: 5%; at least 8.0-fold (0.90 log units) between middle value and limit.
By their numbers in this assay, from the lowest: compounds 3 and 2 (each within the scatter of the next); then compound 1. At a limit, above all of these: compound 4.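

For the compounds shown here, the pair of compound 3 and compound 4 isolates the change for the first time: with dimethylamino in place of methoxy on the aromatic carbon next to the ring nitrogen, the step is large, an at least 220-fold higher number from compound 3 to compound 4 (2.34 log units; beyond the scatter). Going by these compounds alone, with dimethylamino in this place, the five-membered group also matters, as thiophen-2-yl in place of thiophen-3-yl gives an at least 5.7-fold higher number from compound 1 to compound 4 (0.75 log units; beyond the scatter), whereas the one step among the methoxy compounds, a different exchange, stays within the scatter at a 1.2-fold lower number from compound 2 to compound 3 (0.09 log units; within the scatter). In this assay, compound 4 gives a limit and not a number: the limit of > 20000 nM in this assay, at which 1 of the 4 values shown sits.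

The compounds shown leave open how a primary amine or a methylamino group would read at this position. They also leave open how thiophen-3-yl behaves alongside methoxy on the shared core.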